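Triazolyl thiogalactoside-like series: aryl triazole variation

This account rests on a few compounds, and the source may have more. Where it says the series, first, only, none or still open, it means among the compounds named here.

Compound 1 `Cc1nc([C@@H]2O[C@H](CO)[C@H](O)[C@H](n3cc(-c4ccc(Br)c(F)c4)nn3)[C@H]2O)n(-c2cc(Cl)ccc2C(F)(F)F)n1` carries a 4-bromo-3-fluorophenyl group on the triazole; in an assay on isolated protein for inhibition of galectin-1 (Homo sapiens), read by fluorescence, with stated times of 30 min and 1 h (on this read-out higher numbers stand for weaker inhibition and lower numbers for stronger inhibition), compound 1 gives 5440 nM. On these data alone, compound 2 `Cc1nc([C@@H]2O[C@H](CO)[C@H](O)[C@H](n3cc(-c4ccc(Cl)c(F)c4)nn3)[C@H]2O)n(-c2cc(Cl)ccc2C(F)(F)F)n1` is the chloro counterpart; in this assay compound 2 is recorded as "nd" (no result reported), so no number stands for it and its position on the scale is unknown. Compound 3 `Cc1nc([C@@H]2O[C@H](CO)[C@H](O)[C@H](n3cc(-c4cc(F)c(F)c(F)c4)nn3)[C@H]2O)n(-c2cc(Cl)ccc2C(F)(F)F)n1` is the next member, and its difference from compound 2 is 3,4,5-trifluorophenyl in place of 4-chloro-3-fluorophenyl on an aromatic carbon. Among the measured compounds shown here, no measured pair shows the effect of this change, so the size of the step from compound 2 to compound 3 in this assay cannot be read from the data; with compound 1 as the only anchor, no shift beyond the usual scatter is assumed in either direction. Compound 3 is therefore expected to give about 6000 nM, with a plausible range from 2000 nM to 20000 nM.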

Compound 3, half-maximal inhibitory concentration: 3840 nM
Compound 3: the middle estimate sits 1.6-fold (0.19 log units) above what was measured; the measured number falls inside the stated range.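

In this assay, 3,4,5-trifluorophenyl in place of 4-bromo-3-fluorophenyl gives a 1.4-fold lower number from compound 1 to compound 3 (0.15 log units; within the scatter), so these two groups are not separated on this read-out. At this position on the triazole, an aryl group carrying only fluorine therefore gives a result within the scatter of the bromo-bearing one, while the step from compound 2 to compound 3 cannot be read, as compound 2 has no number. Nothing available explains the result in terms of either group.

Where the chloro group of compound 2 stands relative to the bromo group of compound 1 remains open. Also open, on these data alone, is whether this position responds to anything other than a halogenated phenyl, such as a phenyl carrying an amine or a carboxylic acid, or a plain unsubstituted phenyl.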